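Inverting both ring stereocentres of a bromopyridine amide

The source may report more compounds than this note shows. Statements on the series, on what has been measured and on what is new or still open speak of the compounds shown alone.

Compound 1 `COc1cc(N2C[C@H]3CCNC[C@H]32)cnc1Br` gives 200 nM.
Compound 2 `N#Cc1cc(N2C[C@H]3CCNC[C@H]32)cnc1Br` gives 172 nM.
Compound 3 `NC(=O)c1cc(N2C[C@@H]3CCNC[C@@H]32)cnc1Br` gives 1490 nM.

Among the three compounds measured in a functional assay on HEK293 cells for agonist activity at Neuronal acetylcholine receptor; alpha4/beta2 (Homo sapiens), read by FLIPR (a higher number here means that more compound is needed for the effect, a lower number that less compound is needed), compound 3 stands highest, well apart from compounds 1 and 2, which lie close to each other: the step of a 1.2-fold lower number from compound 1 to compound 2 (0.07 log units; within the scatter) changes little. Compound 4 `NC(=O)c1cc(N2C[C@H]3CCNC[C@H]32)cnc1Br` has not yet been measured. It differs from compound 3 only in configuration: the two compounds have the same atoms and bonds and differ only in configuration as drawn: 2 of 2 stereo elements differ (all stereocentres are inverted: mirror images); a stereocentre at a saturated ring carbon is drawn S in compound 3 and R in compound 4; a stereocentre at a saturated ring carbon is drawn R in compound 3 and S in compound 4. For the measured compounds named here, the configuration drawn for compound 4 is the one drawn for compounds 1 and 2, while compound 3 is drawn as their mirror image at both ring carbons.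

Going by the values given here, no measured step compares two mirror images, so none bears directly on this change. Among the compounds with values here, the only step available, from compound 1 to compound 2, concerns a substituent on the aromatic ring and says nothing about ring configuration. What can be said is that the two compounds sharing the configuration of compound 4 both give lower numbers than compound 3, though they also carry different aromatic groups. A lower number for compound 4 than for compound 3 is therefore expected, of the size a 4.3-fold lower number from compound 3 to compound 4 (0.63 log units; beyond the scatter), with wide uncertainty. Compound 4 is estimated at 350 nM, within 60 nM to 3000 nM.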

Compound 4, half-maximal effective concentration: 340 nM
For compound 4 the middle estimate is 1.0-fold (0.01 log units) above the measured one; low and high end bracket the measured number.
By their numbers in this assay, from the lowest: compounds 2, 1 and 4 (each within the scatter of the next); then compound 3.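

In this assay, for the compounds shown here, the mirror-image pair gives the first direct reading of ring configuration, with a 4.4-fold lower number from compound 3 to compound 4 (0.64 log units; beyond the scatter) as a modest step, and that gap can be assigned to configuration alone because nothing else separates the two compounds: the fact that compounds 3 and 4 differ only in the configuration as drawn.

With the configuration drawn for compounds 1 and 2 held in place, the carbamoyl group does not set itself apart from the other two aromatic substituents: both a 2.0-fold higher number from compound 2 to compound 4 (0.30 log units; within the scatter) and a 1.7-fold higher number from compound 1 to compound 4 (0.23 log units; within the scatter) are steps that stay inside the usual spread of repeat measurements. Among the steps shown between compounds differing in one place, only the inversion of both ring carbons therefore lies beyond the scatter, while the exchange of methoxy, cyano and carbamoyl does not.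

The compounds shown leave open whether the same inversion would shift the number for the methoxy or cyano compounds, and whether one ring carbon alone would account for the gap. They also leave open how a carboxylic acid or an N-methyl amide in place of carbamoyl would read in either configuration.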